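The compounds below may be only part of what the source reports. "The series", "measured", "known", "first", "only" and "open" are said of these compounds alone.

In a functional assay on HCT-116 cells (Homo sapiens) for inhibition, read by MTT assay, with a stated time of 2 days (a higher number here means a weaker inhibitor of growth, a lower number a stronger inhibitor of growth), compound 1 `Nc1ccccc1NC(=O)CCCNCC(=O)Nc1ccc(Br)cc1` gives 7700 nM while compound 2 `Nc1ccccc1NC(=O)c1ccc(NCC(=O)Nc2cccc([N+](=O)[O-])c2)cc1` gives 1100 nM on the same read-out. Compound 2 thus holds the lower of the two numbers, and its gap to compound 1 lies beyond the scatter. The two compounds differ in more than one place, so the gap is tied to no single change. Going by the values given here, compound 3 `Nc1ccccc1NC(=O)c1ccc(NCC(=O)Nc2ccc(Cl)cc2)cc1` has 4-chlorophenyl in place of 3-nitrophenyl on an amide-type nitrogen, a change counted as 4-chlorophenyl in place of 3-nitrophenyl on an amide-type nitrogen and the only difference from compound 2. Among the compounds with values here, no measured pair shows this exchange, so the data point in neither direction in this assay and no step beyond the scatter is expected. The expected step of a 1.1-fold lower number from compound 2 to compound 3 (0.04 log units; within the scatter) is therefore small and has no favoured direction. Compound 3 is estimated at 1000 nM with an expected range of 400 nM to 2800 nM on that measure.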

Compound 3, concentration for 50% growth inhibition: 4200 nM
Beside the measured number, compound 3's estimate is 4.2-fold (0.62 log units) below it; measured number outside the range, above it.
By their numbers in this assay, from the lowest: compound 2; then compounds 3 and 1 (each within the scatter of the next).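

In this assay, going by these compounds alone, the exchange of 3-nitrophenyl for 4-chlorophenyl on the amide-type nitrogen gives a 3.8-fold higher number from compound 2 to compound 3 (0.58 log units; beyond the scatter) and is the first step in this set that can be tied to a single place. It shows that this position is not indifferent: with the rest of compound 2 held fixed, the change of aryl group alone moves the number beyond the scatter, and the higher number goes with 4-chlorophenyl. No measurement at hand bears on the origin of this step, which therefore stays unexplained.

The exchange alters both the group and the numbered position it occupies, so the compounds shown leave open which of the two goes with the step; 3-chlorophenyl and 4-nitrophenyl on the same nitrogen would separate them. Also open, on these data alone, are how an unsubstituted phenyl or a 3-aminophenyl group would read at this position, and whether the same exchange would give a step of similar size on the core of compound 1.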